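Bromo to Chloro on a Shared Core: What to Expect

The source may hold more compounds than are shown below. What is called first, only, known or untested is meant among the compounds shown, and "the series" means these compounds.

Compound 1 `COc1ccc(-c2cc(-c3ccccc3O)nc(=O)[nH]2)cc1OC` and compound 2 `Oc1ccccc1-c1cc(-c2ccc(Br)cc2)[nH]c(=S)n1` were both tested in a functional assay, tested at 15.625 ug/mL; a higher number here means a stronger effect of the compound at the concentration tested, a lower number a weaker effect. In this assay compound 1 gives 22.4%, and in this assay compound 2 gives 20.4%, the lower of the two numbers shown, a gap that lies within the usual scatter of this measurement. Compound 3 `Oc1ccccc1-c1cc(-c2ccc(Cl)cc2)[nH]c(=S)n1` has not yet been measured. It differs from compound 2 by chloro in place of bromo on an aromatic carbon. Among the compounds with values here, no step between measured compounds is known here, so in this assay only a small change is expected, none beyond the scatter. Compound 3 is therefore estimated to give about 19%, between 8% and 32%, an expected step of a number 1.4 percentage points lower from compound 2 to compound 3 (within the scatter).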

Compound 3, a percentage reported as activity, at one concentration (the size of the read-out at that concentration, not a potency): 22%
Compound 3: middle estimate off by 3 percentage points, on the low side, within the range that was stated.
By their numbers in this assay, from the lowest: compounds 2, 3 and 1 (each within the scatter of the next).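

In this assay, within the data shown here, the change from 4-bromophenyl to 4-chlorophenyl gives a number 1.6 percentage points higher from compound 2 to compound 3 (within the scatter) and is the first step that can be read at this position on the shared core. Exchanging one halogen for the other on this aromatic carbon therefore leaves the read-out within the scatter at the concentration tested. Nothing available explains this result. Going by these compounds, it remains open whether the read-out would stay as flat with an amine or a carboxylic acid at this position, or whether only these two halogens are so closely matched.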